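From 1H-indol-3-yl to 4-methylphenyl on a shared core

The source may report more compounds than this note shows. Statements on the series, on what has been measured and on what is new or still open speak of the compounds shown alone.

Measured in a functional assay on HeLa cells (Homo sapiens) for inhibition, read by CCK-8 assay, with a stated time of 48 h; on this read-out lower numbers stand for stronger inhibition and higher numbers for weaker inhibition (cell growth data for two compounds):
Compound 1 (`COc1cc(-c2ccnc3cc(-c4cn(CO)c5ccccc45)nn23)cc(OC)c1OC`) gives 103 nM
Compound 2 (`COc1cc(-c2ccnc3cc(-c4c[nH]c5ccccc45)nn23)cc(OC)c1OC`) gives 195 nM

Compound 2 stands level with compound 1 on these numbers. Among the measured compounds shown here, the one measured step, a 1.9-fold higher number from compound 1 to compound 2 (0.28 log units; within the scatter) (hydrogen in place of hydroxymethyl on an aromatic nitrogen), is no larger than repeat measurements can differ, so the two cannot be told apart.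

Compound 3 (`COc1cc(-c2ccnc3cc(-c4ccc(C)cc4)nn23)cc(OC)c1OC`) carries a different kind of change, and the difference from compound 2 is counted here: 4-methylphenyl in place of 1H-indol-3-yl on an aromatic carbon. The measured step bears on this only loosely. For the measured compounds named here, it alters a substituent on the 1H-indol-3-yl group but keeps that group, so no measured pair shows what removing it does. A move to a higher number, meaning weaker inhibition, is a judgement rather than a measured trend, and it is expected to exceed the scatter, as an estimated 3.1-fold higher number from compound 2 to compound 3 (0.49 log units; beyond the scatter) (with real uncertainty). Compound 3 is estimated at 600 nM with an expected range from 120 nM to 4000 nM (a deliberately wide span).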

Compound 3, half-maximal inhibitory concentration: 21 nM
Estimate against measurement, compound 3: 29-fold (1.46 log units) above; measured number outside the range, below it.
By their numbers in this assay, from the lowest: compound 3; then compounds 1 and 2 (each within the scatter of the next).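

Among the compounds shown here, at this aromatic carbon, next to the ring nitrogen, the earlier compounds only altered a substituent on the 1H-indol-3-yl group, whereas compound 3 replaces that whole group. In this assay the change to 4-methylphenyl gives a 9.3-fold lower number from compound 2 to compound 3 (0.97 log units; beyond the scatter) and so clearly stronger inhibition, showing that in this pair neither the five-membered ring of the 1H-indol-3-yl group nor its hydrogen-bond donor is required for inhibition of this size, and that a single six-membered carbon ring carrying a methyl group can do better. Nothing available explains why this swap lowers the number.

As far as these compounds go, what remains open is how much of this result belongs to the methyl group itself, a question that a plain phenyl group or a 4-methoxyphenyl group at the same place would help to answer. From the compounds shown here alone, it is also open whether this position would accept a ring bearing an amine or a carboxylic acid, or how a longer chain in place of the methyl group would read out in this assay.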